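From 2-phenylethynyl to 4-methoxyphenyl on a shared core

The source may report more compounds than this note shows. Statements on the series, on what has been measured and on what is new or still open speak of the compounds shown alone.

Compound 1 `Nc1ncnn2c([C@@H]3O[C@H](CO)[C@@H](O)[C@H]3O)cc(C#Cc3cccs3)c12` gives > 100000 nM (a limit)
Compound 2 `Nc1ncnn2c([C@@H]3O[C@H](CO)[C@@H](O)[C@H]3O)cc(C#Cc3ccccc3)c12` gives > 100000 nM (a limit)

Both entries come from a functional assay on K562 cells (Homo sapiens) for antiproliferative activity, with a stated time of 72 h (a lower number here means a stronger inhibitor, a higher number a weaker inhibitor), and neither is a number. The data so far amount to the limit of > 100000 nM in this assay, at which 2 of the 2 values shown sit, and nothing more. Compound 2 therefore stands only at a limit of the assay, with > 100000 nM as its sole entry. Compound 3 `COc1ccc(-c2cc([C@@H]3O[C@H](CO)[C@@H](O)[C@H]3O)n3ncnc(N)c23)cc1` carries 4-methoxyphenyl in place of 2-phenylethynyl on an aromatic carbon. Within the data shown here, the only measured step is a step that the two limits leave unreadable from compound 1 to compound 2 and so offers no size to carry over. No clear step is therefore expected in this assay in either direction, and compound 3 will most likely report the same limit. For compound 3 the estimated value is 60000 nM with an expected range from 15000 nM to 100000 nM as a rough guide. This estimate means an expected at least 1.6-fold lower number from compound 2 to compound 3 (0.22 log units; that floor lies within the scatter) at most nominally.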

Compound 3, half-maximal inhibitory concentration: 76400 nM
Compound 3: the middle estimate sits 1.3-fold (0.10 log units) below what was measured; the range from low to high includes it.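

In this assay compound 3 gives 76400 nM, so this aromatic carbon, with 4-methoxyphenyl on it and no triple bond, yields a measured number. Compound 1 and compound 2 gave only limits, and the step between those two limits cannot be read. Putting 4-methoxyphenyl in place of 2-phenylethynyl gives an at least 1.3-fold lower number from compound 2 to compound 3 (0.11 log units; that floor lies within the scatter), and putting it in place of 2-(thiophen-2-yl)ethynyl gives an at least 1.3-fold lower number from compound 1 to compound 3 (0.11 log units; that floor lies within the scatter), so neither step establishes a real change. Most of the series still sits at a limit: the limit of > 100000 nM in this assay, at which 2 of the 3 values shown sit.

The compounds shown do not separate the loss of the triple bond from the arrival of the methoxy oxygen. Nor do they say how an unsubstituted phenyl, or a 4-aminophenyl carrying an amine, would read at this carbon.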